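This account rests on a few compounds, and the source may have more. Where it says the series, first, only, none or still open, it means among the compounds named here.

Working notes on a series sharing one core carrying a bis(4-fluorophenyl)methyl group and an acetic acid side chain. Compound 1 `NS(=O)(=O)c1ccc(-c2nc(C(c3ccc(F)cc3)c3ccc(F)cc3)sc2CC(=O)O)cc1` gives 1500 nM in an in vitro assay on HEK385-7 cells for displacement of a labelled ligand from prostaglandin D2 receptor 2 (Homo sapiens); on this read-out higher numbers stand for weaker inhibition and lower numbers for stronger inhibition. Compound 2 `O=C(O)Cc1sc(C(c2ccc(F)cc2)c2ccc(F)cc2)nc1-c1ccncc1` gives 5.3 nM in this assay. Among the measured compounds shown here, the single measured step, a 280-fold lower number from compound 1 to compound 2 (2.45 log units; beyond the scatter), is large and beyond the scatter. For the measured compounds named here, compound 2 thus stands at the lower of the two numbers so far, with compound 1 the higher by that step.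

Compound 3 `O=C(O)Cc1sc(C(c2ccc(F)cc2)c2ccc(F)cc2)nc1-c1ccnc(Cl)c1` differs from compound 2 by chloro in place of hydrogen on an aromatic carbon, the chloro sitting next to the ring nitrogen. Going by the values given here, no measured step bears on this position: the one step known exchanges the entire aryl ring rather than adding a substituent to it, so it sets no scale for a single chloro. Compound 3 is therefore expected to give about 6 nM in this assay, with a range of 2 nM to 20 nM. The expected step of a 1.1-fold higher number from compound 2 to compound 3 (0.05 log units; within the scatter) is estimated to stay within the scatter.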

Compound 3, half-maximal inhibitory concentration: 3.1 nM
Estimate against measurement, compound 3: 1.9-fold (0.29 log units) above; the range from low to high includes it.
By their numbers in this assay, from the lowest: compounds 3 and 2 (each within the scatter of the next); then compound 1.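

In this assay, a substituent on the pyridin-4-yl ring can now be read: chloro in place of hydrogen next to the ring nitrogen gives a 1.7-fold lower number from compound 2 to compound 3 (0.23 log units; within the scatter), which is within the scatter, so on this read-out this position accepts a chlorine atom with no change that can be told from repeat variation. The exchange of 4-sulfamoylphenyl for 2-chloropyridin-4-yl gives a 480-fold lower number from compound 1 to compound 3 (2.68 log units; beyond the scatter), beyond the scatter, so the large gap to compound 1 persists with the chloro present. Nothing available here accounts for either step.

From the compounds shown here alone, whether a methyl group, a methoxy group or an amine at this same position would also stay within the scatter of compound 2 remains open. A single chloro also does not show how the acetic acid side chain would behave if replaced by a longer chain.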